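A Bulkier Amide Side Chain on a Non-Toxic Scaffold

The source may report more compounds than this note shows. Statements on the series, on what has been measured and on what is new or still open speak of the compounds shown alone.

Compound 1 `CCC(=O)NCc1ccc(C(=O)Nc2ccc(C)c(Nc3nccc(-c4cccnc4)n3)c2)cc1` was examined in an ADME assay on BaF3 cells (Mus musculus) for cytotoxicity, read by CellTiter-Glo and CCK-8 assay, with a stated time of 72 h; a higher number here means a weaker inhibitor of growth, a lower number a stronger inhibitor of growth. In this assay compound 1 gives > 10000 nM, which is a limit of the assay and not a number. Compound 2 `CCC(=O)N(CCN(C)C)Cc1ccc(C(=O)Nc2ccc(C)c(Nc3nccc(-c4cccnc4)n3)c2)cc1` carries 2-(dimethylamino)ethyl in place of hydrogen on an amide-type nitrogen, and in this assay compound 2 gives > 10000 nM, again a limit. Compound 3 `C/C=C/C(=O)N(CCN(C)C)Cc1ccc(C(=O)Nc2ccc(C)c(Nc3nccc(-c4cccnc4)n3)c2)cc1` has prop-1-en-1-yl in place of ethyl on a carbonyl carbon, and in this assay compound 3 gives > 10000 nM, also a limit. The step that the two limits leave unreadable from compound 1 to compound 2 is therefore unreadable, as are a step that the two limits leave unreadable from compound 1 to compound 3 and a step that the two limits leave unreadable from compound 2 to compound 3, because of the limit of > 10000 nM in this assay, at which 3 of the 3 values shown sit. Compound 4 `CCCC(=O)N(CCN(C)C)Cc1ccc(C(=O)Nc2ccc(C)c(Nc3nccc(-c4cccnc4)n3)c2)cc1` differs from compound 1 by (2-(dimethylamino)ethyl)(propylcarbonyl)amino in place of propanoylamino on a saturated chain carbon bound to an aromatic carbon. The nearest measured change, from compound 1 to compound 2, stayed at the limit, so no step beyond the scatter is expected, and a limit is again the most likely report. Compound 4 is expected to give about 20000 nM, with a range from 8000 nM to 60000 nM. This is expected to amount to a step that the limit leaves unreadable from compound 1 to compound 4.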

Compound 4, concentration for 50% growth inhibition: > 10000 nM
Compound 4 ended at the assay's limit (the forecaster's own chance of this, stated with the estimate: 85%); the middle value does not contradict the limit.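

No step can be read among compound 1, compound 2, compound 3 and compound 4, because all four end at the same limit: the limit of > 10000 nM in this assay, at which 4 of the 4 values shown sit.

The compounds shown leave open whether these amide side chains differ at all in this assay, and what change to the shared core would yield a readable value.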